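A few compounds are considered here, and "the series" means these few. Any claim that something is new, unique, unknown or untested is made for them only; others in the source may bear on it.

Compound 1 `CCc1cc(C#N)ccc1Nc1c(N[C@H](C)CC(C)(C)C)c(=O)c1=O`: 90 nM
Compound 2 `CCC(C)(C)NC1C(=O)C(=O)C1c1cccnc1`: > 30000 nM, a limit of the assay

Both compounds were tested in a functional assay for inhibition, with Rattus norvegicus as the target; a higher number here means a weaker inhibitor, a lower number a stronger inhibitor. Among the compounds with values here, compound 1 gives 90 nM, and it is the only compound here with an actual number. Compound 2 is reported only as a limit, > 30000 nM, so no exact gap can be stated and the position of compound 1 rests on this single reading.

The next compound to be tested is compound 3 `C[C@H](CC(C)(C)C)Nc1c(Nc2ccc(C#N)cc2)c(=O)c1=O`. It keeps the core of compound 1 but carries hydrogen in place of ethyl on an aromatic carbon.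

Within the data shown here, no pair of measured compounds differs in one place only, so no measured step in this assay can serve as a guide. The expectation therefore starts from compound 1 at 90 nM, and it is a modest step toward a weaker inhibitor, one that may not clear the usual scatter. The expected change is a 1.7-fold higher number from compound 1 to compound 3 (0.22 log units; within the scatter). For compound 3 the estimated value is 150 nM, with an expected range from 30 nM to 700 nM.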

Compound 3, half-maximal inhibitory concentration: 370 nM
Compound 3: the middle estimate sits 2.5-fold (0.39 log units) below what was measured, within the range that was stated.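

In this assay, within the data shown here, the change from ethyl to hydrogen gives the first measured step, a 4.1-fold higher number from compound 1 to compound 3 (0.61 log units; beyond the scatter) and this step lies beyond the scatter. At this aromatic carbon, ortho to a large group and meta to a cyano group, ethyl and hydrogen are therefore not interchangeable: the compound with ethyl is the stronger inhibitor of this pair, yet with hydrogen in its place compound 3 still gives a measurable 370 nM rather than a limit of the assay. Nothing among the data shown accounts for the size of this step.

Going by these compounds, whether a methyl group, a propyl chain or a chlorine atom on the same carbon would give a value closer to that of compound 1 or to that of compound 3 remains open, so it cannot yet be told how the effect of this position grows with the group placed there. On these data alone, it also remains open whether the step would keep its size if the branched amine chain on the shared core were replaced by a cyclohexyl amine.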